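Acyl urea thiazole hydrazones: halogen swap on the benzoyl ring

The source may hold more compounds than are shown below. What is called first, only, known or untested is meant among the compounds shown, and "the series" means these compounds.

Three members of this series have a number in a functional assay on A549 cells (Homo sapiens) for inhibition, read by MTT assay, with a stated time of 72 h; on this read-out lower numbers stand for stronger inhibition and higher numbers for weaker inhibition. Compound 1 `Cc1nc(N(C)C(=O)NC(=O)c2c(F)cccc2F)sc1C(=O)N/N=C/c1ccc(C(F)(F)F)cc1` gives 60.5 ug/mL in this assay. Compound 2 `CN(C(=O)NC(=O)c1ccc([N+](=O)[O-])cc1)c1nc(C(F)(F)F)c(C(=O)N/N=C/c2cccc(C(F)(F)F)c2)s1` gives 5.42 ug/mL in this assay. Compound 3 `CN(C(=O)NC(=O)c1ccc(Cl)c(Cl)c1)c1nc(C(F)(F)F)c(C(=O)N/N=C/c2ccc([N+](=O)[O-])cc2)s1` gives 6.44 ug/mL in this assay. On these three numbers compound 3 sits next to compound 2, the gap between them within the scatter of repeated measurement, so no order between those two can be claimed; compound 1 stands apart with a number beyond the scatter higher than that of compound 3, which here means weaker inhibition for compound 1.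

Compound 4 `CN(C(=O)NC(=O)c1ccc(F)c(F)c1)c1nc(C(F)(F)F)c(C(=O)N/N=C/c2ccc([N+](=O)[O-])cc2)s1` is not yet measured. It differs from compound 3 in one place: 3,4-difluorophenyl in place of 3,4-dichlorophenyl on a carbonyl carbon. For the measured compounds named here, no step of this kind between two measured compounds exists, so there is nothing to calibrate the change against; the expectation rests on compound 3 alone. A small step from compound 3 to compound 4 is expected, a 1.3-fold higher number from compound 3 to compound 4 (0.12 log units; within the scatter), towards a somewhat higher number, but not clearly beyond the scatter. Compound 4 is therefore estimated at 8.5 ug/mL in this assay, with a range from 3.5 ug/mL to 20 ug/mL.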

Compound 4, half-maximal inhibitory concentration: 5.78 ug/mL
Compound 4: the middle estimate sits 1.5-fold (0.17 log units) above what was measured, and the stated range covers the measured number.
By their numbers in this assay, from the lowest: compounds 2, 4 and 3 (each within the scatter of the next); then compound 1.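

Exchanging 3,4-dichlorophenyl for 3,4-difluorophenyl on a carbonyl carbon gives the series its first comparison that differs in one place, and in this assay it reads as a 1.1-fold lower number from compound 3 to compound 4 (0.05 log units; within the scatter). No difference in inhibition can therefore be claimed between these two halogen patterns, and on this read-out the position accepts either one while the rest of compound 3 stays unchanged. The compounds shown come with no measurement that would account for this result, so the observation stands as a plain comparison of two numbers.

On these data alone, the step covers only two halogens on one phenyl ring, so what a 3,4-dimethoxyphenyl, a pyridine ring or an aminophenyl group would do on this carbonyl carbon stays open. It also rests on a single background carrying 4-nitrophenyl at the far end of the hydrazone, and whether the same exchange reads the same way with another group there, such as a morpholine ring or a carboxylic acid, remains an open question for the series.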